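Ethoxycarbonyl to hydroxymethyl: working notes on the series

The source may hold more compounds than are shown below. What is called first, only, known or untested is meant among the compounds shown, and "the series" means these compounds.

In a functional assay on K562 cells (Homo sapiens) for cytotoxicity, read by MTT assay, with a stated time of 48 h (a higher number here means a weaker inhibitor, a lower number a stronger inhibitor), compound 1 `COc1cc([C@@H]2C[C@]2(CO)C(=O)NCc2ccc(C)cc2)cc(OC)c1OC` gives > 100000 nM, which is a limit and not a number. Compound 2 `CCOC(=O)[C@@]1(C(=O)NCc2ccc(C)cc2)C[C@@H]1c1cc(OC)c(OC)c(OC)c1` gives > 100000 nM, also a limit. Compound 2 therefore stands at the only level seen so far: the limit of > 100000 nM in this assay, at which 2 of the 2 values shown sit. Compound 3 `COc1cc([C@H]2C[C@@]2(CO)C(=O)NCc2ccc(C)cc2)cc(OC)c1OC` has hydroxymethyl in place of ethoxycarbonyl on a saturated ring carbon of the three-membered ring (hydroxymethyl in place of ethoxycarbonyl on a saturated ring carbon). Among the compounds with values here, no measured step is available, and on that single level no change beyond the scatter is expected in this assay, so the expected step is a number no higher from compound 2 to compound 3 (the limit leaves the size open). For compound 3 the estimate is 100000 nM, with an expected range of 30000 nM to 200000 nM.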

Compound 3, half-maximal inhibitory concentration: > 100000 nM
Compound 3 was reported as a limit; the forecaster's own chance of this, stated with the estimate: 65%; the middle value lies on the limit itself.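

Compound 3 also gives only a limit in this assay, so no step from compound 1 or compound 2 to compound 3 can be read: the limit of > 100000 nM in this assay, at which 3 of the 3 values shown sit.

Going by these compounds, whether hydroxymethyl in place of ethoxycarbonyl, or the configuration as drawn, changes the read-out at all stays open.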